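This account rests on a few compounds, and the source may have more. Where it says the series, first, only, none or still open, it means among the compounds named here.

Measured so far:
compound 1 `CC1=CC[C@H](C(C)C)c2cc(C)c(OC(=O)c3ccc([N+](=O)[O-])cc3)cc21` — 36.7%
compound 2 `CC1=CC[C@H](C(C)C)c2cc(C)c(OC(=O)c3cccc(C(F)(F)F)c3)cc21` — 25.4%

Two esters of the same core have been measured in a functional assay on PC-3 cells (Homo sapiens) for antiproliferative activity, read by sulforhodamine B assay, with a stated time of 48 h, tested at 50 uM; on this read-out higher numbers stand for more inhibition at the one concentration tested (going by the name of the read-out) and lower numbers for less inhibition. Compound 1 gives 36.7%, and compound 2 gives 25.4%. Compound 2 thus stands lowest of the two numbers, with compound 1 sitting above it by a gap beyond the usual scatter. Compound 3 `CC1=CC[C@H](C(C)C)c2cc(C)c(OC(=O)c3cccc([N+](=O)[O-])c3)cc21` has not yet been measured. It differs from compound 2 in one place: nitro in place of trifluoromethyl on an aromatic carbon. Among the compounds with values here, no step between measured compounds covers this exchange, so the expectation rests on the two values shown. Since compound 1, which also carries a nitro group, reaches 36.7%, a modest rise is expected for compound 3, of a size a number 6.6 percentage points higher from compound 2 to compound 3 (within the scatter) that may not exceed the scatter. In this assay compound 3 is therefore estimated at 32%, within a range from 18% to 46%.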

Compound 3, a percentage reported as inhibition, at one concentration (the size of the read-out at that concentration, not a potency): 36.9%
For compound 3 the middle estimate is 4.9 percentage points below the measured one; the range from low to high includes it.
By their numbers in this assay, from the lowest: compound 2; then compounds 1 and 3 (each within the scatter of the next).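

In this assay, nitro in place of trifluoromethyl on this aromatic carbon gives a step beyond the scatter (a number 11.5 percentage points higher from compound 2 to compound 3 (beyond the scatter)), so the read-out responds to which of these two groups sits at this place. Shifting the nitro group shows no such response: with 3-nitrophenyl in place of 4-nitrophenyl on the carbonyl carbon, the step lies within the scatter (a number 0.2 percentage points higher from compound 1 to compound 3 (within the scatter)), and these two nitro esters cannot be told apart here. Nothing available explains either step.

On these data alone, it remains open where other groups at this place, such as an amine, a carboxylic acid or a nitrile, would fall relative to nitro and trifluoromethyl. All the esters shown also keep the shared core unchanged, so the effect of any change to the core remains open too.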